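Pyridin-4-yl in Place of 4-Chlorophenyl: What to Expect

A few compounds are considered here, and "the series" means these few. Any claim that something is new, unique, unknown or untested is made for them only; others in the source may bear on it.

In a functional assay on the whole organism (Hindlimb) for inhibition, with Mus musculus as the target, with a stated time of 4 h (a lower number here means that less compound is needed, a higher number that more compound is needed for the effect), the three measured compounds give these minimum effective doses:

compound 1 `CC1(C)CC12NC(=O)N(NC(=O)c1ccc(Cl)cc1)C2=O` — 300 mg/kg
compound 2 `CC1(C)CC12NC(=O)N(NC(=O)c1ccc([N+](=O)[O-])cc1)C2=O` — 300 mg/kg
compound 3 `CN(C)c1ccc(C(=O)NN2C(=O)NC3(CC3(C)C)C2=O)cc1` — 300 mg/kg

Compound 1 stands level with compounds 2 and 3 within the scatter. Compound 4 `CC1(C)CC12NC(=O)N(NC(=O)c1ccncc1)C2=O` differs from compound 1 by pyridin-4-yl in place of 4-chlorophenyl on a carbonyl carbon. Among the measured compounds shown here, the steps that bear on this are no change at the digits printed from compound 1 to compound 2 (within the scatter), no change at the digits printed from compound 1 to compound 3 (within the scatter) and no change at the digits printed from compound 2 to compound 3 (within the scatter): each replaced one group on the aromatic ring and none moved the dose. The present change alters the ring itself, so those steps guide only loosely, but nothing measured points to a shift. The expected step is no change at the digits printed from compound 1 to compound 4 (within the scatter), that is none beyond the scatter. Compound 4 is therefore estimated at 300 mg/kg, within 100 mg/kg to 600 mg/kg.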

Compound 4, minimum effective dose: 300 mg/kg
Estimate against measurement, compound 4: no gap at the digits printed, within the range that was stated.
By their numbers in this assay, from the lowest: compounds 1, 2, 3 and 4 (each within the scatter of the next).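

Changing the ring itself, and not only a group on it, also leaves the dose unmoved in this assay (no change at the digits printed from compound 1 to compound 4 (within the scatter)). At this place on the carbonyl carbon, then, the reading stays the same with a ring nitrogen and its hydrogen-bond acceptor, and with one heavy atom fewer. No measurement explains this flat result.

On these data alone, all four compounds read alike, so whether any group at this place can lower the dose stays open. A cyclohexyl ring or a carboxylic acid in place of pyridin-4-yl would test that.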